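A Larger Ester on Compound 3

The source may report more compounds than this note shows. Statements on the series, on what has been measured and on what is new or still open speak of the compounds shown alone.

In an ADME assay on HeLa cells (Homo sapiens) for cytotoxicity, read by MTT assay, with a stated time of 2 days (on this read-out higher numbers stand for lower toxicity in this test and lower numbers for higher toxicity in this test), compound 1 (`CNC(=O)c1cc(Oc2ccc3c(C)c(C(=O)OC)sc3c2)ccn1`) gives 15700 nM and compound 2 (`CCOC(=O)c1cc2ccc(Oc3ccccc3)cc2s1`) gives 90100 nM while compound 3 (`CNC(=O)c1cc(Oc2ccc3ccc(C(=O)OC)cc3c2)ccn1`) gives 33800 nM and so holds the middle place, with both gaps beyond the scatter. Compound 4 (`CCC(C)OC(=O)c1ccc2ccc(Oc3ccnc(C(=O)NC)c3)cc2c1`) has sec-butyl in place of methyl on an oxygen next to a carbonyl group. For the measured compounds named here, no pair of measured compounds differs in one place, so the data offer no direct guide to this change. The step expected in this assay (a 1.4-fold lower number from compound 3 to compound 4 (0.13 log units; within the scatter)) is none beyond the scatter, with a slight lean toward lower numbers. Compound 4 is estimated at 25000 nM with an expected range from 10000 nM to 65000 nM on this read-out.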

Compound 4, half-maximal cytotoxic concentration: 9000 nM
The estimate for compound 4 lay 2.8-fold (0.44 log units) above the measured number; the whole stated range lies above it.
By their numbers in this assay, from the lowest: compounds 4 and 1 (each within the scatter of the next); then compound 3; then compound 2.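

This is the first change in a single place among these compounds, and it shows that the group on this oxygen is not silent in this assay. Sec-butyl in place of methyl gives a 3.8-fold lower number from compound 3 to compound 4 (0.57 log units; beyond the scatter) and so moves the read-out toward higher toxicity in this test, by a modest step beyond the scatter. Nothing measured here accounts for this step.

For the compounds shown here, with only two groups at this position, it remains open whether the number keeps falling along a series such as isopropyl or a longer chain. A carboxylic acid at the same place would show how the read-out behaves with no alkyl group on this oxygen.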